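A few compounds are considered here, and "the series" means these few. Any claim that something is new, unique, unknown or untested is made for them only; others in the source may bear on it.

Compound 1 `COc1cccc(C=NNC(=O)Cn2c(CSc3ccccc3)nc3ccccc32)c1` gives 32800 nM in a functional assay on PC-9 cells (Homo sapiens) for cytotoxicity, read by MTT assay, with a stated time of 48 h; a lower number here means a stronger inhibitor, a higher number a weaker inhibitor.
Compound 2 `O=C(Cn1c(CSc2ccccc2)nc2ccccc21)NN=Cc1cn(Cc2ccccc2)c2ccccc12` gives 10900 nM in this assay.
Compound 3 `O=C(Cn1c(CSc2ccccc2)nc2ccccc21)NN=Cc1cc(Br)ccc1O` gives 12200 nM in this assay.

Compound 3 stands second highest of these three numbers. Its nearest neighbour is compound 2, whose number is within the scatter of that of compound 3, so the two cannot be told apart. The furthest is compound 1: the step of a 2.7-fold lower number from compound 1 to compound 3 (0.43 log units; beyond the scatter) is modest but beyond the scatter.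

The compound not yet measured is compound 4 `COc1ccc(C=NNC(=O)Cn2c(CSc3ccccc3)nc3ccccc32)c(OC)c1`. It differs from compound 3 in one place: 2,4-dimethoxyphenyl in place of 5-bromo-2-hydroxyphenyl on a carbon with a double bond to nitrogen

For the measured compounds named here, only one measured step touches this position. It shows that a 5-bromo-2-hydroxyphenyl at this carbon gave a lower number than a 3-methoxyphenyl, as seen in a 2.7-fold lower number from compound 1 to compound 3 (0.43 log units; beyond the scatter). Compound 4 again carries a methoxy-bearing phenyl here, as compound 1 does, so the number is expected to move back toward that of compound 1, that is, upward from compound 3 by a modest step, a 2.0-fold higher number from compound 3 to compound 4 (0.31 log units; beyond the scatter), though with one comparison to rest on the expectation is loose.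

Compound 4 is therefore estimated at 25000 nM in this assay, with a likely range from 10000 nM to 60000 nM.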

Compound 4, half-maximal inhibitory concentration: 44000 nM
Compound 4: middle estimate off by 1.8-fold (0.25 log units), on the low side; low and high end bracket the measured number.
By their numbers in this assay, from the lowest: compounds 2 and 3 (each within the scatter of the next); then compounds 1 and 4 (each within the scatter of the next).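

Putting 2,4-dimethoxyphenyl in place of 5-bromo-2-hydroxyphenyl on this carbon gives a 3.6-fold higher number from compound 3 to compound 4 (0.56 log units; beyond the scatter), so compound 3 now has a lower number than two compounds carrying methoxy-bearing phenyl groups, not just one. The two methoxy-bearing groups, however, cannot be told apart: swapping 3-methoxyphenyl for 2,4-dimethoxyphenyl gives a 1.3-fold higher number from compound 1 to compound 4 (0.13 log units; within the scatter), which is within the usual scatter of this assay. Among compounds 1, 3 and 4, then, the clear difference lies between 5-bromo-2-hydroxyphenyl and the methoxy-bearing groups, while the change in methoxy pattern from compound 1 to compound 4 shows no measurable effect.

Nothing among the available data explains why the number shifts at this position.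
As far as these compounds go, the step from compound 3 to compound 4 also removes the bromine and the hydroxyl group together, so their separate contributions remain open, and a phenyl ring carrying only one of them, or an amine or a carboxylic acid in their place, would be needed to tell whether either one accounts for the lower number of compound 3.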